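A group exchange on the way to compound 4

This account rests on a few compounds, and the source may have more. Where it says the series, first, only, none or still open, it means among the compounds named here.

Compound 1 `Cc1cc(C)cc(S(=O)(=O)c2c(C(=O)N[C@H]3CCNC3)[nH]c3ccc(Cl)cc23)c1`: 10000 nM
Compound 2 `Cc1cc(C)cc(S(=O)(=O)c2c(C(=O)N[C@@H]3CCN(Cc4ccccc4C#N)C3)[nH]c3ccc(Cl)cc23)c1`: >= 186000 nM
Compound 3 `Cc1cc(C)cc(S(=O)(=O)c2c(C(=O)N[C@H]3CCN(Cc4n[nH]c(=O)n4C)C3)[nH]c3ccc(Cl)cc23)c1`: 21500 nM

In an ADME assay on MT4 cells (Homo sapiens) for cytotoxicity, read by MTT assay, with a stated time of 5 days (on this read-out lower numbers stand for higher toxicity in this test and higher numbers for lower toxicity in this test), compound 3, at 21500 nM, holds the higher of the two exact numbers. Compound 2 is reported only as a limit, >= 186000 nM, and it also carries the 2-cyanophenyl group. Compound 4 `Cc1cc(C)cc(S(=O)(=O)c2c(C(=O)N[C@H]3CCN(Cc4ccccc4C#N)C3)[nH]c3ccc(Cl)cc23)c1` brings that group to compound 3, on a saturated chain carbon bound to an amine nitrogen in a ring: a group of 8 heavy atoms (7 carbon, 1 nitrogen; one six-membered aromatic ring of carbon only) in place of a group of 7 heavy atoms (3 carbon, 3 nitrogen, 1 oxygen; one five-membered aromatic ring with 3 hetero atoms), on a saturated chain carbon bound to an amine nitrogen in a ring. Among the compounds with values here, the one measured step bearing on this is a 2.2-fold higher number from compound 1 to compound 3 (0.33 log units; beyond the scatter), which brings in the group that now leaves. A modest further rise in this assay is therefore expected, with a 1.9-fold higher number from compound 3 to compound 4 (0.27 log units; within the scatter) as the estimated step. Compound 4 is estimated at 40000 nM, with an expected range of 12000 nM to 190000 nM.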

Compound 4, half-maximal cytotoxic concentration: > 228000 nM
Compound 4: no number, only a limit; the forecaster's own chance of this, stated with the estimate: 40%; at least 5.7-fold (0.75 log units) between middle value and limit.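

In this assay, the 2-cyanophenyl group gives an at least 10-fold higher number from compound 3 to compound 4 (1.02 log units; beyond the scatter), and 2-cyanobenzyl in place of hydrogen on an amine nitrogen in a ring gives an at least 22-fold higher number from compound 1 to compound 4 (1.35 log units; beyond the scatter). The size of the change at this position thus depends strongly on the group that enters, which the modest step to compound 3 alone did not show. Compound 4 is reported only as a limit, > 228000 nM.

From the compounds shown here alone, compounds 2 and 4 both carry limits, so the step between them cannot be read and the role of configuration stays open: the fact that compounds 2 and 4 differ only in the configuration as drawn. Going by these compounds, how a plain benzyl group, without the nitrile, would read in this assay also stays open.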